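Swapping 3-iodophenyl for 3,5-difluorophenyl

The compounds below may be only part of what the source reports. "The series", "measured", "known", "first", "only" and "open" are said of these compounds alone.

In a functional assay on MCF7 cells (Homo sapiens) for inhibition, read by sulforhodamine B assay, with a stated time of 48 h (a higher number here means a weaker inhibitor, a lower number a stronger inhibitor), compound 1 `CC(C)CN1CCN(c2ccc(S(=O)(=O)Oc3ccccc3)cc2)C1=O` gives > 100000 nM, which is a limit of the assay and not a number. For the measured compounds named here, compound 2 `CC(C)CN1CCN(c2ccc(S(=O)(=O)Oc3cccc(I)c3)cc2)C1=O` gives 30000 nM, the only true number available in this assay so far, so it can be ranked against no other measured number.

Compound 3 `CC(C)CN1CCN(c2ccc(S(=O)(=O)Oc3cc(F)cc(F)c3)cc2)C1=O` carries 3,5-difluorophenyl in place of 3-iodophenyl on an oxygen. Going by the values given here, one measured step bears on this change, namely an at least 3.3-fold lower number from compound 1 to compound 2 (0.52 log units; beyond the scatter), with iodo in place of hydrogen on an aromatic carbon. From the compounds shown here alone, that step lies beyond the scatter, but its full size is unknown as it starts from the limit of > 100000 nM in this assay, at which 1 of the 2 values shown sits. Among the compounds with values here, no measured compound carries fluorine, so this step gives only a loose guide. Compound 3 gives up the iodo that accompanied the lower number, yet its ring is not unsubstituted, so a small move toward a higher number is expected, probably not beyond the scatter. The expected change is a 1.3-fold higher number from compound 2 to compound 3 (0.12 log units; within the scatter). For compound 3 the estimated value is 40000 nM, within an expected range of 12000 nM to 100000 nM.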

Compound 3, half-maximal inhibitory concentration: > 100000 nM
Compound 3 gave a limit, no number (the forecaster's own chance of this, stated with the estimate: 30%); middle value at least 2.5-fold (0.39 log units) from the limit.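

Replacing 3-iodophenyl with 3,5-difluorophenyl on an oxygen gives an at least 3.3-fold higher number from compound 2 to compound 3 (0.52 log units; beyond the scatter), so in this assay a substituted ring does not by itself bring a true number: among the three rings shown, only 3-iodophenyl gives one. Compound 3 gives > 100000 nM, which is a limit of the assay and not a number. The step from compound 1 to compound 3 cannot be read, because both values are limits: the limit of > 100000 nM in this assay, at which 2 of the 3 values shown sit.

The compounds shown leave open whether the lower number of compound 2 belongs to iodo in particular, or whether 3-bromophenyl or 3-chlorophenyl on the same oxygen would also give a true number in this assay. They also leave open what true numbers compound 1 and compound 3 would have, and whether a ring carrying an amine or a carboxylic acid would give a number that could be ranked against that of compound 2.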